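The compounds below may be only part of what the source reports. "The series", "measured", "known", "first", "only" and "open" are said of these compounds alone.

Measured so far in an assay on CHO cells for displacement of a labelled ligand from prostaglandin E2 receptor EP1 subtype (Homo sapiens); a higher number here means a weaker inhibitor, a lower number a stronger inhibitor:

- compound 1, `COc1ccc(Cc2nnc(CN(c3cccc(C(F)(F)F)c3C)S(=O)(=O)c3ccc(C)cc3)o2)cc1`: 63.1 nM
- compound 2, `COc1ccc(Cc2nnc(CN(c3cccc(Cl)c3C)S(=O)(=O)c3ccc(C)cc3)o2)cc1`: 6.31 nM
- compound 3, `COc1ccc(Cc2nnc(CN(c3cccc(Cl)c3Cl)S(=O)(=O)c3ccc(C)cc3)o2)cc1`: 7.94 nM

Compound 2 carries the lowest number of the three in this assay. Against compound 1 the gap is clear: a 10-fold lower number from compound 1 to compound 2 (1.00 log units; beyond the scatter). Against compound 3 it is not: a 1.3-fold higher number from compound 2 to compound 3 (0.10 log units; within the scatter), so the two cannot be ordered. The step of a 7.9-fold lower number from compound 1 to compound 3 (0.90 log units; beyond the scatter) is of the same kind as the first, and both of these steps change the aryl group on the sulfonamide nitrogen only.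

Compound 4, `Cc1ccc(S(=O)(=O)N(Cc2nnc(Cc3cccc(F)c3)o2)c2cccc(Cl)c2C)cc1`, is not yet measured. Relative to compound 2 the change is 3-fluorophenyl in place of 4-methoxyphenyl on a saturated chain carbon bound to an aromatic carbon. The aryl on the sulfonamide nitrogen and the rest of the shared core are kept as in compound 2.

For the measured compounds named here, no measured step touches this benzyl position; the three steps above all concern the other aryl group. Going by the values given here, there is therefore no direct precedent for the size or direction of the step from compound 2 to compound 4 in this assay. With nothing to push the number either way, the working expectation is a step within the scatter, with a wider band than usual to cover a change at an untested position: a 1.6-fold higher number from compound 2 to compound 4 (0.20 log units; within the scatter) is the estimated step. Compound 4 is thus expected to give about 10 nM in this assay, in the range 3 nM to 40 nM.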

Compound 4, half-maximal inhibitory concentration: 316 nM
Beside the measured number, compound 4's estimate is 32-fold (1.50 log units) below it; measured number above the stated range.
By their numbers in this assay, from the lowest: compounds 2 and 3 (each within the scatter of the next); then compound 1; then compound 4.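

In this assay, the saturated chain carbon bound to an aromatic carbon proves to be a place where a single change can cost far more than any earlier step showed: a 50-fold higher number from compound 2 to compound 4 (1.70 log units; beyond the scatter). That step is larger than the widest one seen on the sulfonamide nitrogen aryl, a 10-fold lower number from compound 1 to compound 2 (1.00 log units; beyond the scatter), so in this series the 4-methoxybenzyl end of the molecule cannot be treated as a passive part of the shared core. Nothing available accounts for the size of this step, and the measured values alone give no cause for it.

The step replaces 4-methoxybenzyl with 3-fluorobenzyl, so the substituent and its numbered place on the ring change together, and the compounds shown cannot separate what the loss of the methoxy contributes from what the entering fluoro contributes. Open too, from the compounds shown here alone, is how a plain benzyl group, a 3-methoxybenzyl group or a 4-hydroxybenzyl group would read in this assay on the same core, and whether the chloro and trifluoromethyl steps on the other aryl group would keep their size with 3-fluorobenzyl in place.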